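Aryl variation on the triazole nitrogen: compound 3 to compound 4

This account rests on a few compounds, and the source may have more. Where it says the series, first, only, none or still open, it means among the compounds named here.

Measured in a functional assay on A-431 cells (Homo sapiens) for cytotoxicity, read by MTT assay, with a stated time of 24 h; on this read-out higher numbers stand for weaker inhibition and lower numbers for stronger inhibition:
compound 1 `COc1ccc(/C=C\C(=O)O)c(OCc2cn(-c3ccccc3I)nn2)c1CC=C(C)C`: 32700 nM
compound 2 `COc1ccc(-n2cc(COc3c(/C=C\C(=O)O)ccc(OC)c3CC=C(C)C)nn2)cc1`: "not determined" (no result reported)
compound 3 `COc1cccc(-n2cc(COc3c(/C=C\C(=O)O)ccc(OC)c3CC=C(C)C)nn2)c1`: 23200 nM

In this assay compound 3 gives 23200 nM, the lowest of the two numbers, with compound 1 nearest at 32700 nM; the step of a 1.4-fold lower number from compound 1 to compound 3 (0.15 log units; within the scatter) lies within the scatter. Compound 2 has no result.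

Compound 4 `COc1ccc(/C=C\C(=O)O)c(OCc2cn(-c3ccccc3F)nn2)c1CC=C(C)C` differs from compound 3 in one place: 2-fluorophenyl in place of 3-methoxyphenyl on an aromatic nitrogen. Among the compounds with values here, the one measured step bearing on this position, a 1.4-fold lower number from compound 1 to compound 3 (0.15 log units; within the scatter), exchanged one aryl group for another on the same nitrogen and stayed within the scatter, so no shift beyond the scatter is expected here either. Compound 4 is estimated at 28000 nM (range 12000 nM to 65000 nM), an expected step of a 1.2-fold higher number from compound 3 to compound 4 (0.08 log units; within the scatter).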

Compound 4, half-maximal inhibitory concentration: 12400 nM
Compound 4: middle estimate off by 2.3-fold (0.35 log units), on the high side, within the range that was stated.
By their numbers in this assay, from the lowest: compounds 4, 3 and 1 (each within the scatter of the next, the first and the last beyond it).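

Fluoro in place of iodo on an aromatic carbon gives the first step at this position beyond the scatter in this assay: there is a 2.6-fold lower number from compound 1 to compound 4 (0.42 log units; beyond the scatter) and it is modest. Within the data shown here, replacing the whole aryl group gives a 1.9-fold lower number from compound 3 to compound 4 (0.27 log units; within the scatter) and stays within the scatter, so the series so far does not separate 2-fluorophenyl from 3-methoxyphenyl. No measurement at hand explains the halogen step.

On these data alone, whether chloro or bromo in the same place would give numbers lying between those of compound 4 and compound 1 stays open. So does the effect of an amine on this aryl ring.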